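The source may hold more compounds than are shown below. What is called first, only, known or untested is meant among the compounds shown, and "the series" means these compounds.

Measured so far:
compound 1, `O=C(Nc1ccccc1OC(F)(F)F)Nc1n[nH]c2ccccc12`: 30500 nM
compound 2, `Nc1nn(C(=O)Nc2ccc(Cc3ccccc3)cc2)c2ccccc12`: 495 nM

Both compounds were tested in a functional assay on SF-539 cells (Homo sapiens) for inhibition, read by sulforhodamine B assay, with a stated time of 48 h; a lower number here means a stronger inhibitor of growth, a higher number a weaker inhibitor of growth. Compound 1 gives 30500 nM, while compound 2 gives 495 nM, the lowest of the two numbers; the gap between them lies well beyond the usual scatter, so compound 2 is the stronger inhibitor of growth of the pair.

The next compound, compound 3, `CCCCOc1ccc(NC(=O)n2nc(N)c3ccccc32)cc1`, is not yet measured. It keeps the core of compound 2 and changes one group on the outer ring: butoxy in place of benzyl on an aromatic carbon. The group that leaves carries a ring of its own; the group that enters is an open chain with an oxygen that can accept a hydrogen bond.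

For the measured compounds named here, no measured pair shows what such a change does here, so the expectation rests on compound 2 alone. With only its value of 495 nM as an anchor, the step from compound 2 to compound 3 is expected to be small, a 1.6-fold higher number from compound 2 to compound 3 (0.21 log units; within the scatter), most likely toward a slightly weaker inhibitor, but not clearly beyond the scatter. Compound 3 is therefore estimated at 800 nM, within a range of 250 nM to 2600 nM.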

Compound 3, concentration for 50% growth inhibition: 17800 nM
The estimate for compound 3 lay 22-fold (1.35 log units) below the measured number, and the stated range ends below it.
By their numbers in this assay, from the lowest: compound 2; then compounds 3 and 1 (each within the scatter of the next).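

In this assay this position on the outer ring, para to a large group, proves highly sensitive: butoxy in place of benzyl gives a 36-fold higher number from compound 2 to compound 3 (1.56 log units; beyond the scatter) on an otherwise unchanged molecule. Here the benzyl group, with its ring, goes with the stronger inhibitor of growth, while the open butoxy chain with its oxygen goes with the weaker one, but the two groups differ in ring, size and oxygen at once, so this single pair cannot show which difference matters. No measurement at hand explains the step.

A phenoxy group would keep a ring and carry an oxygen, so it could help separate the role of the ring from that of the oxygen. A pentyl chain would likewise show how an open chain without oxygen fares at this position.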